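The compounds below may be only part of what the source reports. "The series", "measured", "known", "first", "only" and "open" are said of these compounds alone.

Working notes on the series.

Compound 1 `CC1=CC[C@H](C(C)(C)NC(=S)NN)CC1` is the hydrazinecarbothioamide parent. In an ADME assay on Vero cells (Chlorocebus sabaeus) for inhibition, read by sulforhodamine B assay, with a stated time of 48 h (on this read-out higher numbers stand for weaker inhibition of growth and lower numbers for stronger inhibition of growth), compound 1 reaches only > 100000 nM, which is a limit of the assay and not a number. Compound 2 `CC1=CC[C@H](C(C)(C)NC(=S)N/N=C/c2ccccc2)CC1` likewise stops at > 100000 nM in this assay, again a limit. Among the measured compounds shown here, compound 3 `CC1=CC[C@H](C(C)(C)NC(=S)N/N=C/c2ccco2)CC1` is the one member with a real number, giving 14700 nM in this assay. The two measured steps both point the same way: an at least 6.8-fold lower number from compound 1 to compound 3 (0.83 log units; beyond the scatter) and an at least 6.8-fold lower number from compound 2 to compound 3 (0.83 log units; beyond the scatter), each only a lower bound because of the limit of > 100000 nM in this assay, at which 2 of the 3 values shown sit.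

Compound 4 `CC1=CC[C@H](C(C)(C)NC(=S)N/N=C/c2ccc[nH]2)CC1` differs from compound 1 as follows: a group of 7 heavy atoms (5 carbon, 2 nitrogen; one five-membered aromatic ring with 1 hetero atom) in place of one nitrogen atom, on an amide-type nitrogen. For the measured compounds named here, the change closely parallels the one from compound 1 to compound 3, which replaced the same nitrogen by a furan-bearing group, so in this assay a step of similar size and direction is expected, an at least 5.0-fold lower number from compound 1 to compound 4 (0.69 log units; beyond the scatter), with the caveat that the furan step itself is only bounded from one side. Compound 4 is therefore estimated at 20000 nM, within 7000 nM to 100000 nM, in this assay.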

Compound 4, concentration for total growth inhibition: > 100000 nM
Compound 4: a limit, no number (the forecaster's own chance of this, stated with the estimate: 30%); at least 5.0-fold (0.69 log units) between middle value and limit.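

On a carbon with a double bond to nitrogen, 1H-pyrrol-2-yl in place of furan-2-yl in this assay gives an at least 6.8-fold higher number from compound 3 to compound 4 (0.83 log units; beyond the scatter), so a five-membered aromatic ring alone does not bring the lower number. Among the compounds shown, only furan-2-yl does, and changing the ring hetero atom is enough to lose it. The steps from compound 1 and from compound 2 to compound 4 cannot be read because both ends of each are limits: the limit of > 100000 nM in this assay, at which 3 of the 4 values shown sit.

From the compounds shown here alone, whether thiophen-2-yl or a methyl-substituted furan-2-yl would keep a measurable value, as compound 3 does, remains open. Also open, going by these compounds, is whether the furan-2-yl result in compound 3 would hold with a carbonyl in place of the thiocarbonyl.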